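A ring swap in a series that has barely moved

The compounds below may be only part of what the source reports. "The series", "measured", "known", "first", "only" and "open" are said of these compounds alone.

compound 1 `COc1cccc(C=C(C(=O)/C=C/c2cccc(OC)c2OC)C(=O)/C=C/c2cccc(OC)c2OC)c1OC`: 320 nM
compound 2 `COc1cccc(/C=C/C(=O)C(=Cc2ccc(O)c(F)c2)C(=O)/C=C/c2cccc(OC)c2OC)c1OC`: 200 nM
compound 3 `COc1cccc(/C=C/C(=O)C(=Cc2ccc(OC)c(OC)c2OC)C(=O)/C=C/c2cccc(OC)c2OC)c1OC`: 260 nM

All three compounds were tested in a functional assay on A549 cells (Homo sapiens) for antiproliferative activity, read by sulforhodamine B assay, with a stated time of 48 h; on this read-out higher numbers stand for weaker inhibition and lower numbers for stronger inhibition. They share a core and differ only in the ring on a double-bonded chain carbon bound to a double-bonded chain carbon. Compound 3 is not clearly separated from either of the others: the data show a 1.2-fold lower number from compound 1 to compound 3 (0.09 log units; within the scatter), and also a 1.3-fold higher number from compound 2 to compound 3 (0.11 log units; within the scatter).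

Compound 4 `COc1ccc(C=C(C(=O)/C=C/c2cccc(OC)c2OC)C(=O)/C=C/c2cccc(OC)c2OC)cc1O` changes that same ring, with 3-hydroxy-4-methoxyphenyl in place of 2,3,4-trimethoxyphenyl on a double-bonded chain carbon bound to a double-bonded chain carbon.

The measured swaps at this place are the best guide. Besides the two steps above, the data show a 1.6-fold lower number from compound 1 to compound 2 (0.20 log units; within the scatter). Three different rings have therefore given numbers that cannot be told apart, so no step beyond the scatter is expected here. Going by the values given here, compound 2 is the only measured compound with a hydroxy group on this ring, and it gives 200 nM. That supports at most a slight expected lean towards its value, and only as a tentative guess.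

The estimated change is a 1.2-fold lower number from compound 3 to compound 4 (0.09 log units; within the scatter). For compound 4 the estimated value is 210 nM, with an expected range of 100 nM to 420 nM.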

Compound 4, half-maximal inhibitory concentration: 270 nM
For compound 4 the middle estimate is 1.3-fold (0.11 log units) below the measured one; the range from low to high includes it.
By their numbers in this assay, from the lowest: compounds 2, 3, 4 and 1 (each within the scatter of the next).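

In this assay, a hydroxy group and one methoxy group on the ring, in place of three methoxy groups, leave the number essentially unchanged, with a 1.0-fold higher number from compound 3 to compound 4 (0.02 log units; within the scatter). The other two comparisons read the same way, with a 1.4-fold higher number from compound 2 to compound 4 (0.13 log units; within the scatter) and a 1.2-fold lower number from compound 1 to compound 4 (0.07 log units; within the scatter), so a fourth ring joins the others without separating from any of them. This ring has fewer heavy atoms than 2,3,4-trimethoxyphenyl and a hydrogen-bond donor that group lacks, yet the two rings with a hydroxy group cannot be told apart from the two without one, and nothing available here accounts for this flat picture.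

On these data alone, all four rings carry only methoxy, hydroxy or fluoro groups, so it remains open whether any change at this place can move the number beyond the scatter, for instance an amine, a carboxylic acid or a longer chain such as butoxy on the ring. The compounds shown also leave open whether the flat picture would hold in cells other than A549, or whether the shared core matters more than this ring.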